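A few compounds are considered here, and "the series" means these few. Any claim that something is new, unique, unknown or untested is made for them only; others in the source may bear on it.

In a functional assay on PC-3 cells (Homo sapiens) for cytotoxicity, read by MTT assay, with a stated time of 72 h (a higher number here means a weaker inhibitor, a lower number a stronger inhibitor), the measured members of the series read as follows: compound 1 `CCCCCCCCNc1nc(SCc2ccc(C(F)(F)F)cc2)nc2ccccc12` gives 10500 nM; compound 2 `CCOc1ccccc1Nc1nc(SCc2ccc(C(F)(F)F)cc2)nc2ccccc12` gives 26200 nM; compound 3 `FC(F)(F)c1ccc(CSc2nc(Nc3ccc(Cl)cc3)c3ccccc3n2)cc1` gives 7110 nM.

Compound 2 stands highest of the three numbers, and is the least potent of them: the step of a 2.5-fold higher number from compound 1 to compound 2 (0.40 log units; beyond the scatter) and the step of a 3.7-fold lower number from compound 2 to compound 3 (0.57 log units; beyond the scatter) both lie beyond the scatter, whereas the step of a 1.5-fold lower number from compound 1 to compound 3 (0.17 log units; within the scatter) does not.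

Compound 4 `Fc1ccc(Nc2nc(SCc3ccc(C(F)(F)F)cc3)nc3ccccc23)cc1Cl` differs from compound 2 at the nitrogen on the aromatic ring: 3-chloro-4-fluorophenyl in place of 2-ethoxyphenyl on a nitrogen on an aromatic ring. The step that bears on this is a 3.7-fold lower number from compound 2 to compound 3 (0.57 log units; beyond the scatter), in which the same 2-ethoxyphenyl gave way to another substituted phenyl, 4-chlorophenyl. The entering 3-chloro-4-fluorophenyl is, like 4-chlorophenyl, a halogen-bearing phenyl, so a step of similar size and in the same direction, toward a lower number, is expected here, with the usual uncertainty of a single comparison.

Compound 4 is therefore estimated at 8500 nM, within a range of 3500 nM to 20000 nM. That estimate means a step of a 3.1-fold lower number from compound 2 to compound 4 (0.49 log units; beyond the scatter), expected but not yet confirmed.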

Compound 4, half-maximal inhibitory concentration: 18600 nM
Beside the measured number, compound 4's estimate is 2.2-fold (0.34 log units) below it, within the range that was stated.
By their numbers in this assay, from the lowest: compounds 3, 1, 4 and 2 (each within the scatter of the next, the first and the last beyond it).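

In this assay, a halogen-bearing phenyl at this nitrogen does not by itself separate a compound from its neighbours: a 1.4-fold lower number from compound 2 to compound 4 (0.15 log units; within the scatter) and a 1.8-fold higher number from compound 1 to compound 4 (0.25 log units; within the scatter) both stay within the scatter. The substitution pattern on the halogen-bearing phenyl matters more here, with a 2.6-fold higher number from compound 3 to compound 4 (0.42 log units; beyond the scatter), so 4-chlorophenyl and 3-chloro-4-fluorophenyl cannot be treated as interchangeable. Nothing available explains this difference.

Still open, as far as these compounds go, is whether the gap between compound 3 and compound 4 follows from the 3-chloro placement or from the 4-fluoro atom, which 3-chlorophenyl and 4-fluorophenyl groups on this nitrogen would separate. Also open, from the compounds shown here alone, is how a phenyl carrying a carboxylic acid or an amine-bearing chain would read at this position.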